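Working notes: from compound 3 to compound 4

The source may report more compounds than this note shows. Statements on the series, on what has been measured and on what is new or still open speak of the compounds shown alone.

Values so far in a functional assay on HepG2 cells (Homo sapiens) for inhibition, read by MTT assay, with a stated time of 3 days; a higher number here means a weaker inhibitor, a lower number a stronger inhibitor

- compound 1 `CC[C@H](C)[C@@H](NCC(=O)NNC(=O)COc1ccc(-c2nc3ccccc3s2)cc1OC)C(=O)O` gives 3990 nM
- compound 2 `CCOC(=O)[C@@H](NCC(=O)NNC(=O)COc1ccc(-c2nc3ccccc3s2)cc1OC)[C@@H](C)CC` gives 3460 nM
- compound 3 `CCOC(=O)[C@H](CS(=O)(=O)O)NCC(=O)NNC(=O)COc1ccc(-c2nc3ccccc3s2)cc1OC` gives 3360 nM

Compound 3 does not stand apart from the other two, with a 1.2-fold lower number from compound 1 to compound 3 (0.07 log units; within the scatter) and a 1.0-fold lower number from compound 2 to compound 3 (0.01 log units; within the scatter) as its steps, so no order can be read among the three.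

Next comes compound 4 `CCOC(=O)[C@@H]1CCCN1CC(=O)NNC(=O)COc1ccc(-c2nc3ccccc3s2)cc1OC` with 2-(ethoxycarbonyl)pyrrolidin-1-yl in place of (1-(ethoxycarbonyl)-2-sulfoethyl)amino on a saturated chain carbon bound to a carbonyl carbon as its change, that is 2-(ethoxycarbonyl)pyrrolidin-1-yl in place of (1-(ethoxycarbonyl)-2-sulfoethyl)amino on a saturated chain carbon bound to a carbonyl carbon.

Within the data shown here, three measured steps bear on this. Swapping 1-carboxy-2-methylbutyl for 1-(ethoxycarbonyl)-2-methylbutyl gave a 1.2-fold lower number from compound 1 to compound 2 (0.06 log units; within the scatter) as its result, and sulfomethyl in place of sec-butyl gave a 1.0-fold lower number from compound 2 to compound 3 (0.01 log units; within the scatter) as its result. Neither change moved the number beyond the scatter. None of the three measured compounds carries a ring at this place, so the data do not test the pyrrolidine ring itself, and the range is kept wide for that reason.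

In this assay the expected change is a 1.0-fold higher number from compound 3 to compound 4 (0.01 log units; within the scatter) with no step beyond the scatter and no direction foreseen.

Compound 4 is estimated at 3400 nM with an expected range of 1500 nM to 7000 nM for this measurement.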

Compound 4, half-maximal inhibitory concentration: 2800 nM
For compound 4 the middle estimate is 1.2-fold (0.08 log units) above the measured one, within the range that was stated.
By their numbers in this assay, from the lowest: compounds 4, 3, 2 and 1 (each within the scatter of the next).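

In this assay, among these compounds, a ring now stands at this place for the first time: 2-(ethoxycarbonyl)pyrrolidin-1-yl on a saturated chain carbon bound to a carbonyl carbon gives a 1.2-fold lower number from compound 3 to compound 4 (0.08 log units; within the scatter) against the sulfo-bearing chain, a 1.2-fold lower number from compound 2 to compound 4 (0.09 log units; within the scatter) against the ester-bearing chain and a 1.4-fold lower number from compound 1 to compound 4 (0.15 log units; within the scatter) against the acid-bearing chain. The series therefore shows that the open chain can give way to a five-membered non-aromatic ring, and the group entering with 0 hydrogen-bond donors can replace one with 2, without the number leaving the scatter. No measurement on hand offers a reason for how flat these steps are.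

The compounds shown leave open whether a pyrrolidine carrying a carboxylic acid instead of the ethoxycarbonyl, a piperidine ring or a plain dimethylamino group at this place would move the number beyond the scatter. They also leave open whether any group at this place can do so, since every step among the four compounds stays within it.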